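Changing the amide of compound 1: a permeability estimate

This account rests on a few compounds, and the source may have more. Where it says the series, first, only, none or still open, it means among the compounds named here.

Within the data shown here, compound 1 `O=C(c1ccc([C@H]2[C@@H](F)[C@@H](F)C[C@@H](F)[C@H]2F)cc1)N1CC(O)C1` stands highest of the two numbers known so far. In an ADME assay on MDCK-MDR1 cells (Canis lupus familiaris) for permeability, in the apical to basolateral direction, with a stated time of 180 min (a lower number here means that the compound crosses the layer more slowly, a higher number that the compound crosses the layer faster), compound 1 gives 6.7 10^-6 cm/s, while compound 2 `CC(=O)N1CC(C(=O)Nc2ccc([C@H]3[C@@H](F)[C@@H](F)C[C@@H](F)[C@H]3F)cc2)C1` gives 0.6 10^-6 cm/s, a gap beyond the usual scatter. Compound 3 `CN(CCC#N)C(=O)c1ccc([C@H]2[C@@H](F)[C@@H](F)C[C@@H](F)[C@H]2F)cc1` is the next step; its change from compound 1 is (2-cyanoethyl)(methyl)amino in place of 3-hydroxyazetidin-1-yl on a carbonyl carbon. Among the measured compounds shown here, no step between measured compounds is known, so the direction rests on compound 1 alone, and a modest rise in this assay is expected, near the edge of the scatter. For compound 3 the estimated value is 12 10^-6 cm/s, with a range from 5 10^-6 cm/s to 25 10^-6 cm/s, so the expected step is a 1.8-fold higher number from compound 1 to compound 3 (0.25 log units; within the scatter).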

Compound 3, apparent permeability: 8.1 10^-6 cm/s
Compound 3: the middle estimate sits 1.5-fold (0.17 log units) above what was measured; measured number inside the range.
By their numbers in this assay, from the lowest: compound 2; then compounds 1 and 3 (each within the scatter of the next).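

In this assay there is a 1.2-fold higher number from compound 1 to compound 3 (0.08 log units; within the scatter) when (2-cyanoethyl)(methyl)amino stands in place of 3-hydroxyazetidin-1-yl on a carbonyl carbon. Among these compounds, this is the first single-place comparison at this position: compound 1 and compound 3 lie within the scatter of each other, although the four-membered ring and the hydrogen-bond donor both leave in this one change. No supporting measurement is available to explain this result.
As far as these compounds go, whether losing the ring or the donor alone would give the same outcome remains open. So does the outcome with a carboxylic acid or an amine-bearing chain on this carbonyl carbon.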